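A Phenyl in Place of Ethoxy

The source may report more compounds than this note shows. Statements on the series, on what has been measured and on what is new or still open speak of the compounds shown alone.

In a functional assay on A549 cells (Homo sapiens) for inhibition, read by sulforhodamine B assay, with a stated time of 48 h (on this read-out lower numbers stand for stronger inhibition and higher numbers for weaker inhibition), compound 1 `O=c1c([C@@H]2C[C@H](c3ccccc3)ON2c2ccccc2)coc2ccc(F)cc12` gives 51500 nM and compound 2 `CCO[C@H]1C[C@@H](c2coc3ccc(C)cc3c2=O)N(c2ccccc2)O1` gives 20700 nM as the lower of the two numbers, a gap beyond the scatter. The change to compound 3 `Cc1ccc2occ([C@@H]3C[C@H](c4ccccc4)ON3c3ccccc3)c(=O)c2c1` from compound 2 is phenyl in place of ethoxy on a saturated ring carbon. Compound 1 also carries phenyl on that carbon and stands at 51500 nM in this comparison, so a moderate step toward weaker inhibition is expected in this assay on going to compound 3. The estimated step is a 1.7-fold higher number from compound 2 to compound 3 (0.23 log units; within the scatter) toward the higher number. Compound 3 is expected at 35000 nM with 13000 nM to 90000 nM as its estimated range.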

Compound 3, half-maximal inhibitory concentration: 49000 nM
Estimate against measurement, compound 3: 1.4-fold (0.15 log units) below; the measured number falls inside the stated range.
By their numbers in this assay, from the lowest: compound 2; then compounds 3 and 1 (each within the scatter of the next).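

In this assay, among the compounds shown here, phenyl in place of ethoxy on the saturated ring carbon next to the ring oxygen gives a 2.4-fold higher number from compound 2 to compound 3 (0.37 log units; beyond the scatter) as a direct one-place comparison, which the earlier compounds could not provide. With phenyl kept on that carbon, methyl in place of fluoro on an aromatic carbon gives a 1.1-fold lower number from compound 1 to compound 3 (0.02 log units; within the scatter) and so separates the two compounds by no more than the scatter. Nothing available explains either step. The compounds shown leave open how a methoxy group or an amine on that saturated ring carbon would compare with ethoxy, and whether methyl and fluoro would also read alike with ethoxy there.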